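Aryl substitution on the pyridine-linked phenyl and glucagon receptor binding

The compounds below may be only part of what the source reports. "The series", "measured", "known", "first", "only" and "open" are said of these compounds alone.

Measured so far:
compound 1, `CCCCCc1c(C(C)C)nc(C(C)C)c(CO)c1-c1ccc(F)cc1F`, 11000 nM
compound 2, `CCCCCc1c(C(C)C)nc(C(C)C)c(CO)c1-c1ccc(F)c(F)c1`, 1100 nM
compound 3, `CCCCCc1c(C(C)C)nc(C(C)C)c(CO)c1-c1cccc(OC)c1`, 48000 nM

In an assay on CHO cells for inhibition of Glucagon receptor (Homo sapiens) (a lower number here means a stronger inhibitor, a higher number a weaker inhibitor), compound 1 holds the second highest of the three numbers; its nearest neighbour is compound 3, its furthest compound 2. Compound 4, `CCCCCc1c(C(C)C)nc(C(C)C)c(CO)c1-c1ccc(F)c(CO)c1`, is not yet measured. It differs from compound 1 in one place: 4-fluoro-3-(hydroxymethyl)phenyl in place of 2,4-difluorophenyl on an aromatic carbon.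

Going by the values given here, two measured steps bear on this change. Moving from a 2,4-difluorophenyl to a 3,4-difluorophenyl gave a 10-fold lower number from compound 1 to compound 2 (1.00 log units; beyond the scatter), while exchanging the 2,4-difluorophenyl for a 3-methoxyphenyl gave a 4.4-fold higher number from compound 1 to compound 3 (0.64 log units; beyond the scatter). Compound 4 keeps the fluorine in the 4-position, as compound 2 does, yet carries an oxygen-bearing group in the 3-position, as compound 3 does. The two precedents pull in opposite directions, so a modest step in this assay is expected, leaning toward a lower number because of a 10-fold lower number from compound 1 to compound 2 (1.00 log units; beyond the scatter). For compound 4 the estimate is 5000 nM, within 1000 nM to 25000 nM, an expected step of a 2.2-fold lower number from compound 1 to compound 4 (0.34 log units; beyond the scatter).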

Compound 4, half-maximal inhibitory concentration: 19000 nM
The estimate for compound 4 lay 3.8-fold (0.58 log units) below the measured number, and the stated range covers the measured number.
By their numbers in this assay, from the lowest: compound 2; then compounds 1 and 4 (each within the scatter of the next); then compound 3.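

In this assay, the 4-fluoro-3-(hydroxymethyl)phenyl group cannot be separated from 2,4-difluorophenyl, with a 1.7-fold higher number from compound 1 to compound 4 (0.24 log units; within the scatter) lying within the scatter. Going by these compounds alone, the low number of compound 2 does not survive the single exchange of hydroxymethyl for fluoro, which gives a 17-fold higher number from compound 2 to compound 4 (1.24 log units; beyond the scatter), so the fluorine kept in compound 4 is not enough on its own to retain it. Against the 3-methoxyphenyl group, a 2.5-fold lower number from compound 3 to compound 4 (0.40 log units; beyond the scatter) is a much smaller step, and of the groups shown only 3,4-difluorophenyl stands clearly apart at this position.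

No measured property of these groups accompanies the binding numbers, and nothing here accounts for the steps. Still open, going by these compounds, is whether an aminomethyl group, a carboxylic acid or a chloro group in place of the hydroxymethyl group would approach compound 2 or stay with compound 4.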